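The source may report more compounds than this note shows. Statements on the series, on what has been measured and on what is new or still open speak of the compounds shown alone.

Measured so far:
Compound 1 `COC(=O)c1ccc2c(c1)nc(Cn1c(=O)n(C(C)C)c3ccccc31)n2CCC(C)C`: 33700 nM
Compound 2 `CC(C)CCn1c(Cn2c(=O)n(C(C)C)c3ccccc32)nc2cc(C(=O)N(C)C)ccc21`: 25600 nM

In an ADME assay on HEp-2 cells (Homo sapiens) for cytotoxicity (a higher number here means that more compound is tolerated, a lower number that less compound is tolerated), compound 2 gives 25600 nM. Within the data shown here, that places it level with compound 1, since the only measured step is a 1.3-fold lower number from compound 1 to compound 2 (0.12 log units; within the scatter). With just two values, little can be said about the range this series may cover.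

The next compound, compound 3 `CC(C)CCn1c(Cn2c(=O)n(C(C)C)c3ccccc32)nc2cc(N)ccc21`, has amino in place of dimethylcarbamoyl on an aromatic carbon. This change removes the whole carbonyl-bearing group, whereas the measured step only exchanged methoxy for dimethylamino on a carbonyl carbon. That step therefore bears on the new change only loosely. Among the measured compounds shown here, it shows that one swap left this assay within the scatter, but no measured compound yet carries an amino group.

With no evidence for a particular direction, no clear shift beyond the scatter is expected, though the uncertainty is wide. The expected step is a 1.3-fold lower number from compound 2 to compound 3 (0.11 log units; within the scatter). For compound 3 the estimated value is 20000 nM, with an expected range from 7000 nM to 60000 nM.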

Compound 3, half-maximal cytotoxic concentration: 32200 nM
Estimate against measurement, compound 3: 1.6-fold (0.21 log units) below; the measured number falls inside the stated range.
By their numbers in this assay, from the lowest: compounds 2, 3 and 1 (each within the scatter of the next).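

In this assay, a much larger swap than the earlier one, on the same aromatic carbon of the six-membered aromatic ring of carbon only, still leaves the number level: dimethylcarbamoyl with 5 heavy atoms gives way to amino with 1 heavy atom, and a 1.3-fold higher number from compound 2 to compound 3 (0.10 log units; within the scatter) is all that results. Amino in place of methoxycarbonyl on that carbon gives a 1.0-fold lower number from compound 1 to compound 3 (0.02 log units; within the scatter) as well, so compounds 1, 2 and 3 all lie within the scatter of one another, with or without a carbonyl on this carbon. No outside measurement is available to explain why the numbers stay level.

The compounds shown leave open whether a carboxylic acid, a longer chain or a chlorine atom on this aromatic carbon would also stay within the scatter, or whether some group here would move the number clearly. They also leave open how this assay responds to swaps elsewhere on the shared core, since all three compounds differ only at this one carbon.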